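Another Aryl Swap on the Aromatic Nitrogen

The source may report more compounds than this note shows. Statements on the series, on what has been measured and on what is new or still open speak of the compounds shown alone.

Compound 1 `COc1ccc(-n2nncc2CN2C(=O)C3(C(C#N)=C(N)Oc4c3c3nc5ccccc5nc3c3ccccc43)c3ccccc32)cc1`: > 50000 nM, a limit.
Compound 2 `Cc1ccc(Cl)cc1-n1nncc1CN1C(=O)C2(C(C#N)=C(N)Oc3c2c2nc4ccccc4nc2c2ccccc32)c2ccccc21`: > 50000 nM, a limit.

In a functional assay on HCT-116 cells (Homo sapiens) for antiproliferative activity, read by MTT assay, with a stated time of 48 h (a higher number here means a weaker inhibitor, a lower number a stronger inhibitor), compound 1 reaches only a limit, > 50000 nM. Compound 2 likewise reaches only a limit, > 50000 nM. The step that the two limits leave unreadable from compound 1 to compound 2 is therefore unreadable, and compound 2 stands at the limit of > 50000 nM in this assay, at which 2 of the 2 values shown sit. Compound 3 `N#CC1=C(N)Oc2c(c3nc4ccccc4nc3c3ccccc23)C12C(=O)N(Cc1cnnn1-c1ccc(F)c(Cl)c1)c1ccccc12` carries 3-chloro-4-fluorophenyl in place of 5-chloro-2-methylphenyl on an aromatic nitrogen. Among the measured compounds shown here, the single measured step bears on this change but gives no size or direction. Compound 3 is expected to remain at the limit, estimated at 70000 nM with a range of 20000 nM to 250000 nM. The step that the limit leaves unreadable from compound 2 to compound 3 is expected to lie within the scatter.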

Compound 3, half-maximal inhibitory concentration: > 50000 nM
Compound 3 ended at the assay's limit; the forecaster's own chance of this, stated with the estimate: 85%; the middle value lies beyond the limit too.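

In this assay, among the compounds shown here, compound 3 stays at a limit, as do compound 1 and compound 2, so no step among them can be read. The compounds shown leave open whether any aryl group on the aromatic nitrogen would give a measurable value.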